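Cytotoxicity notes: dichlorophenyl ethenyl variant of compound 3

The source may report more compounds than this note shows. Statements on the series, on what has been measured and on what is new or still open speak of the compounds shown alone.

Compound 1 `O=C(/C=C\c1ccccc1)N1N=C(c2ccncc2)OC1c1c[nH]c2ccccc12`, compound 2 `O=C(/C=C\c1ccc(O)cc1)N1N=C(c2ccncc2)OC1c1c[nH]c2ccccc12` and compound 3 `Cc1ccc(/C=C\C(=O)N2N=C(c3ccncc3)OC2c2c[nH]c3ccccc23)cc1` share one core and differ at one aromatic carbon. In an ADME assay on HeLa cells (Homo sapiens) for cytotoxicity, read by MTT assay, with a stated time of 72 h (on this read-out lower numbers stand for stronger inhibition of growth and higher numbers for weaker inhibition of growth), compound 1 gives > 30 ug/mL, which is a limit of the assay and not a number. In this assay compound 2 gives > 30 ug/mL, again a limit. In this assay compound 3 gives > 30 ug/mL, also a limit. Compound 3 thus stands at the limit of > 30 ug/mL in this assay, at which 3 of the 3 values shown sit. The recorded steps a step that the two limits leave unreadable from compound 1 to compound 2, a step that the two limits leave unreadable from compound 1 to compound 3 and a step that the two limits leave unreadable from compound 2 to compound 3 are all unreadable in size for this reason. Compound 4 `O=C(/C=C/c1c(Cl)cccc1Cl)N1N=C(c2ccncc2)OC1c1c[nH]c2ccccc12` differs from compound 3 by 2-(2,6-dichlorophenyl)ethenyl in place of 2-(4-methylphenyl)ethenyl on a carbonyl carbon. For the measured compounds named here, no measured step of this kind is at hand, and none of the three recorded steps moved any compound off the limit. The expected step in this assay is a step that the limit leaves unreadable from compound 3 to compound 4, with no change beyond the scatter foreseen. Compound 4 is estimated at 40 ug/mL, within 15 ug/mL to 100 ug/mL, and is expected most likely to be reported again only as a limit.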

Compound 4, concentration for 50% growth inhibition: > 30 ug/mL
Compound 4 was reported as a limit; the forecaster's own chance of this, stated with the estimate: 75%; the middle value does not contradict the limit.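

In this assay compound 4 gives > 30 ug/mL as a limit of the assay and not a number. For the compounds shown here, no step between compound 4 and compound 1, compound 2 or compound 3 can be read: the limit of > 30 ug/mL in this assay, at which 4 of the 4 values shown sit. The compounds shown leave open how far any of these four compounds inhibits growth in this assay at all, and whether any change at the carbonyl carbon alters that.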